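Nitrile in place of the gem-dimethyl acid on the hexyl chain

This account rests on a few compounds, and the source may have more. Where it says the series, first, only, none or still open, it means among the compounds named here.

Among the compounds with values here, compound 2 `CC(C)(CCCCCCOc1cc(-c2ccccc2)cc(-c2ccccc2)n1)C(=O)O` stands lowest of the two numbers so far in an assay on cell membranes from spleen (Cavia porcellus) for binding affinity to leukotriene B4 receptor 1 (Homo sapiens) (on this read-out higher numbers stand for weaker inhibition and lower numbers for stronger inhibition), giving 22 nM; the nearest is compound 1 `O=C(O)CCCOc1cc(-c2ccccc2)cc(-c2ccccc2)n1`, which in this assay gives 300 nM. Within the data shown here, the single measured step, a 14-fold lower number from compound 1 to compound 2 (1.13 log units; beyond the scatter), is large and favours the longer chain ending in the 4-carboxy-4-methylpentyl group.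

Compound 3 `N#CCCCCCOc1cc(-c2ccccc2)cc(-c2ccccc2)n1` changes compound 2 by cyano in place of 2-carboxy-2-methylpropyl on a saturated chain carbon, five bonds along the chain from an oxygen on an aromatic ring. The chain from the ring oxygen is kept to five saturated carbons, but the acid with its two methyl groups is gone and only a cyano group remains at the end. Among the measured compounds shown here, no measured step removes the acid; the step from compound 1 to compound 2 speaks only to how the acid is carried, not to whether it is needed. Both measured compounds hold a carboxylic acid, so the expectation here is weakly founded. A step in the weaker direction, beyond the scatter, is expected for compound 3, of about an 18-fold higher number from compound 2 to compound 3 (1.26 log units; beyond the scatter). In this assay compound 3 is estimated at 400 nM, within a range from 80 nM to 2000 nM.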

Compound 3, half-maximal inhibitory concentration: 700 nM
Compound 3: the middle estimate sits 1.8-fold (0.24 log units) below what was measured, and the stated range covers the measured number.
By their numbers in this assay, from the lowest: compound 2; then compound 1; then compound 3.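

In this assay, the cyano group in place of 2-carboxy-2-methylpropyl gives a 32-fold higher number from compound 2 to compound 3 (1.50 log units; beyond the scatter), a large step and the first in this set that removes the carboxylic acid from the chain end. The other reading, with 2-cyanoethyl in place of carboxy, gives a 2.3-fold higher number from compound 1 to compound 3 (0.37 log units; beyond the scatter), a modest step beyond the scatter, so among these three compounds the nitrile stands on the weak side of both acids, much further from compound 2 than from compound 1. Nothing available on these compounds accounts for either step.

The step to compound 3 swaps 7 heavy atoms for 2 in one change, taking out the carboxylic acid and both methyl groups together, so the shares of the acid, the methyl groups and the chain end remain unseparated. A carboxylic acid on the same chain without the two methyl groups would help separate them, and a tetrazole or a primary amide at the chain end would show whether anything other than the carboxylic acid can hold the number near that of compound 2.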